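Amino for Chloro on a Shared Core

A few compounds are considered here, and "the series" means these few. Any claim that something is new, unique, unknown or untested is made for them only; others in the source may bear on it.

Compound 1 `Nc1nn(C(=O)Nc2ccc(Cc3ccccc3)cc2)c2ccccc12`: > 100000 nM in a functional assay on SK-MEL-28 cells (Homo sapiens) for antiproliferative activity, read by sulforhodamine B assay, with a stated time of 48 h (on this read-out higher numbers stand for lower toxicity in this test and lower numbers for higher toxicity in this test), a limit of the assay rather than a number.
Compound 2 `Nc1nn(C(=O)Nc2ccc(Cc3ccccc3)cc2)c2ccc(Cl)cc12`: > 100000 nM in this assay, again only a limit.

The step from compound 1 to compound 2, a step that the two limits leave unreadable from compound 1 to compound 2, cannot be read because both values sit at the limit of > 100000 nM in this assay, at which 2 of the 2 values shown sit. Compound 3 `Nc1ccc2c(c1)c(N)nn2C(=O)Nc1ccc(Cc2ccccc2)cc1` differs from compound 2 by amino in place of chloro on an aromatic carbon. Going by the values given here, no measured step gives the size of this change, and both known compounds rest at the limit of > 100000 nM in this assay, at which 2 of the 2 values shown sit, so no step beyond the scatter is expected, with a number no higher from compound 2 to compound 3 (the limit leaves the size open) as the estimated step. For compound 3 in this assay the estimate is 100000 nM, between 30000 nM and 300000 nM, most likely again reported only as a limit.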

Compound 3, concentration lethal to 50% of the cells: 56200 nM
Beside the measured number, compound 3's estimate is 1.8-fold (0.25 log units) above it, within the range that was stated.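

Of the three compounds, only compound 3 gives a number rather than a limit in this assay: the limit of > 100000 nM in this assay, at which 2 of the 3 values shown sit.

Amino on this aromatic carbon gives an at least 1.7-fold lower number from compound 2 to compound 3 (0.25 log units; that floor lies within the scatter) when it replaces chloro, and an at least 1.7-fold lower number from compound 1 to compound 3 (0.25 log units; that floor lies within the scatter) when it replaces hydrogen. From the compounds shown here alone, each step is only a floor, so its true size stays unknown.

Still open, going by these compounds, is whether a methylamino, hydroxyl or methoxy group on the same carbon would also give a number rather than a limit. Also open, on these data alone, is whether amino on another carbon of this ring would do so.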